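Amino substitution on the shared core: cytotoxicity notes

The compounds below may be only part of what the source reports. "The series", "measured", "known", "first", "only" and "open" are said of these compounds alone.

Compound 1 `ClCc1ccc(Cn2cnc3c(Cl)ncnc32)cc1` and compound 3 `ClCc1ccccc1Cn1cnc2c(Cl)ncnc21` are built from the same atoms, joined differently; the difference between the two cores is not broken down here. In a functional assay on SF-295 cells (Homo sapiens) for cytotoxicity, read by sulforhodamine B assay, with a stated time of 48 h (on this read-out lower numbers stand for higher toxicity in this test and higher numbers for lower toxicity in this test), compound 1 gives 24000 nM, while compound 3 gives 51300 nM. Compound 3 stands second highest of the three numbers on record, and its gap to compound 1 is beyond the scatter, so compound 3 is the less toxic of the two in this assay.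

Compound 2 `Nc1nc(Cl)c2ncn(Cc3ccc(CCl)cc3)c2n1` differs from compound 1 by a single change, (amino in place of hydrogen on an aromatic carbon). In this assay compound 2 gives 72400 nM, which is a 3.0-fold higher number from compound 1 to compound 2 (0.48 log units; beyond the scatter). Compound 2 and compound 3 lie within the scatter of each other, so no order between them is claimed.

Compound 4 `Nc1nc(Cl)c2ncn(Cc3ccccc3CCl)c2n1` is not yet measured. It differs from compound 3 by amino in place of hydrogen on an aromatic carbon, and the surroundings of the place are the same as in the earlier change, so this is the same change made on the other core. With only one prior instance of the change among the compounds shown, the expectation rests on that one step. Because the same change gave a 3.0-fold higher number from compound 1 to compound 2 (0.48 log units; beyond the scatter), a step of similar size, a 2.7-fold higher number from compound 3 to compound 4 (0.44 log units; beyond the scatter), is expected from compound 3 to compound 4 in this assay. Compound 4 is therefore estimated to give about 140000 nM in this assay, expected to fall between 60000 nM and 320000 nM; at such numbers the assay may report only a limit.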

Compound 4, concentration lethal to 50% of the cells: 63100 nM
Compound 4: middle estimate off by 2.2-fold (0.35 log units), on the high side; low and high end bracket the measured number.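

Carrying the change to the second core: in this assay amino in place of hydrogen on an aromatic carbon gives a 1.2-fold higher number from compound 3 to compound 4 (0.09 log units; within the scatter) and so no order is claimed between compound 3 and compound 4. For the compounds shown here, this does not show that the change has a different effect on the two cores, although only the step on the core of compound 1 lies beyond the scatter; nor does it show that the step carries over at a fixed size, since two steps in one assay are too few to settle either reading. The two steps cannot be told apart, so the result is best read as compatible with a shared step of uncertain size, and the comparison stands as follows: the same change on two cores in this assay, a 3.0-fold higher number (0.48 log units; beyond the scatter) from compound 1 to compound 2 and a 1.2-fold higher number (0.09 log units; within the scatter) from compound 3 to compound 4, 2.5-fold (0.39 log units) apart, within the scatter of two such steps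

Still open, as far as these compounds go, is whether another group at the same aromatic carbon, such as methylamino, dimethylamino or hydroxyl, would give a step that can be read on either core. Also open, from the compounds shown here alone, is how either core would respond if the chloromethyl group were replaced by a methyl or hydroxymethyl group, and whether the amino step would then look the same.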